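A few compounds are considered here, and "the series" means these few. Any claim that something is new, unique, unknown or untested is made for them only; others in the source may bear on it.

Compound 1 `Cc1ccc(S(=O)(=O)N2C=CNC(=O)[C@H]2CC(=O)N[C@@H]2CCCc3cc(CN(C)C)ccc32)cc1`: 0.21 nM
Compound 2 `Cc1ccc(S(=O)(=O)N2C=CNC(=O)[C@H]2CC(=O)N[C@@H]2CCCc3ccccc32)cc1`: 3.3 nM
Compound 3 `Cc1ccc(S(=O)(=O)N2C=CNC(=O)[C@H]2CC(=O)N[C@@H]2CCc3ccccc32)cc1`: 94.7 nM

In an in vitro functional assay on cells for antagonist activity at B1 bradykinin receptor (Homo sapiens), read by luminescence and calcium flux, with a stated time of 2 h (a higher number here means a weaker inhibitor, a lower number a stronger inhibitor), compound 3 gives the highest number of the three, set apart from compound 2 by a 29-fold higher number from compound 2 to compound 3 (1.46 log units; beyond the scatter) and lying still further from compound 1. Compound 4 `Cc1ccc(S(=O)(=O)N2C=CNC(=O)[C@H]2CC(=O)NC2CCCCC2)cc1` differs from compound 3 by cyclohexyl in place of 2,3-dihydro-1H-inden-1-yl on an amide-type nitrogen. Among the measured compounds shown here, no measured step exchanges a group holding an aromatic ring for one without; the nearest is a 29-fold higher number from compound 2 to compound 3 (1.46 log units; beyond the scatter), where a change of the group on the amide-type nitrogen raised the number sharply, while a 16-fold higher number from compound 1 to compound 2 (1.20 log units; beyond the scatter) concerns a substituent elsewhere. A further change on that side is therefore expected to raise the number again, by about a 4.2-fold higher number from compound 3 to compound 4 (0.63 log units; beyond the scatter). Compound 4 is estimated at 400 nM, within 80 nM to 3000 nM.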

Compound 4, half-maximal inhibitory concentration: 990 nM
For compound 4 the middle estimate is 2.5-fold (0.39 log units) below the measured one, and the stated range covers the measured number.
By their numbers in this assay, from the lowest: compound 1; then compound 2; then compound 3; then compound 4.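

Among the compounds shown here, on the amide-type nitrogen, cyclohexyl in place of 2,3-dihydro-1H-inden-1-yl gives a 10-fold higher number from compound 3 to compound 4 (1.02 log units; beyond the scatter) in this assay, the first change here that leaves that nitrogen's substituent with no aromatic ring. Set against 1,2,3,4-tetrahydronaphthalen-1-yl, which also holds a six-membered non-aromatic ring, the same group gives a 300-fold higher number from compound 2 to compound 4 (2.48 log units; beyond the scatter), so that ring alone does not keep the number of compound 2. Nothing available explains this rise.

Still open, from the compounds shown here alone, is whether a benzyl or phenyl group on that nitrogen would lower the number again. Also open, going by these compounds, is how a dimethylamino group on the cyclohexyl ring would read.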